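Replacing 2-fluoropyridin-4-yl with cyclobutyl on an oxygen

A few compounds are considered here, and "the series" means these few. Any claim that something is new, unique, unknown or untested is made for them only; others in the source may bear on it.

In an ADME assay on the whole organism (plasma, Rattus norvegicus) for protein binding, using cassette dosing, at a dose of 1 mg/kg (a higher number here means a larger unbound share of the compound, a lower number a smaller unbound share), compound 2 (`C[C@@H](Cn1c(=O)[nH]/c(=N\c2ccc(Oc3ccnc(F)c3)cc2)n(Cc2ccc(Cl)cc2)c1=O)C(=O)O`) gives 0.013, the lower of two numbers but within the scatter of the other, from compound 1 (`Cc1cc(/N=c2\[nH]c(=O)n(C[C@H](C)C(=O)O)c(=O)n2Cc2ccc(Cl)cc2)ccc1OC(C)C`). Compound 3 (`C[C@@H](Cn1c(=O)[nH]/c(=N\c2ccc(OC3CCC3)cc2)n(Cc2ccc(Cl)cc2)c1=O)C(=O)O`) carries cyclobutyl in place of 2-fluoropyridin-4-yl on an oxygen on an aromatic ring, with cyclobutyl in place of 2-fluoropyridin-4-yl on an oxygen on an aromatic ring. Among the compounds with values here, no measured pair tests this change directly. Resting on compound 1 at 0.02, no step beyond the scatter is expected in this assay. The estimated change is small, a 1.2-fold higher number from compound 2 to compound 3 (0.09 log units; within the scatter). Compound 3 is expected to give 0.016, within an estimated range of 0.008 to 0.032.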

Compound 3, unbound fraction: 0.015
Beside the measured number, compound 3's estimate is 1.1-fold (0.03 log units) above it, within the range that was stated.
By their numbers in this assay, from the lowest: compounds 2, 3 and 1 (each within the scatter of the next).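

In this assay the change to cyclobutyl gives a 1.2-fold higher number from compound 2 to compound 3 (0.06 log units; within the scatter) at this position, so a non-aromatic carbon ring and 2-fluoropyridin-4-yl on this oxygen cannot be told apart here. The wider exchange of 4-isopropoxy-3-methylphenyl for 4-(cyclobutyloxy)phenyl on a double-bonded nitrogen gives a 1.3-fold lower number from compound 1 to compound 3 (0.12 log units; within the scatter) and likewise separates nothing. No measurement on hand explains these results.

Going by these compounds, whether an amine or a longer chain in place of cyclobutyl on this oxygen would also stay within the scatter in this assay remains open.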